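The compounds below may be only part of what the source reports. "The series", "measured", "known", "first", "only" and "open" are said of these compounds alone.

Working notes on the series. The shared core carries a six-membered non-aromatic ring with 2 nitrogen, and the group on its amine nitrogen is what varies. Compound 1 `COc1ccc(-c2cnc3nc(N)nc(N4CCN(c5ccc(F)cc5)CC4)c3n2)cc1OC` bears 4-fluorophenyl there, and in a functional assay on cells (T-cell, Homo sapiens) for inhibition (a higher number here means a weaker inhibitor, a lower number a stronger inhibitor), compound 1 gives 100 nM. Compound 2 `COc1ccc(-c2cnc3nc(N)nc(N4CCN(Cc5c(Cl)cccc5Cl)CC4)c3n2)cc1OC` bears 2,6-dichlorobenzyl instead, and in this assay compound 2 gives 7600 nM. Among the measured compounds shown here, the one step measured so far, a 76-fold higher number from compound 1 to compound 2 (1.88 log units; beyond the scatter), shows that this position carries most of what separates the two compounds; among the two numbers compound 2 stands highest.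

Compound 3 `COc1ccc(-c2cnc3nc(N)nc(N4CCN(C(=O)CCc5ccccc5)CC4)c3n2)cc1OC` follows from compound 2 by phenethylcarbonyl in place of 2,6-dichlorobenzyl on an amine nitrogen in a ring. For the measured compounds named here, no measured step covers this kind of exchange; the only step that bears on the position is the large one from compound 1 to compound 2, which says the group here can move the number a great deal in either direction. With compound 2 at 7600 nM and compound 1 at 100 nM bracketing the range seen, the expectation for compound 3 in this assay is a partial return toward the lower number, a 3.8-fold lower number from compound 2 to compound 3 (0.58 log units; beyond the scatter), estimated at 2000 nM within 300 nM to 15000 nM.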

Compound 3, half-maximal inhibitory concentration: 100 nM
Estimate against measurement, compound 3: 20-fold (1.30 log units) above; the whole stated range lies above it.
By their numbers in this assay, from the lowest: compounds 1 and 3 (each within the scatter of the next); then compound 2.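

In this assay, the step of a 76-fold lower number from compound 2 to compound 3 (1.88 log units; beyond the scatter) shows that the high number of compound 2 does not hold for every group that places a phenyl ring further out from the amine nitrogen; phenethylcarbonyl, with its carbonyl on that nitrogen, does not share it. Among the compounds shown here, the step showing no change at the digits printed from compound 1 to compound 3 (within the scatter) adds that two quite different groups, 4-fluorophenyl and phenethylcarbonyl, cannot be told apart here, so a carbonyl on this nitrogen and an aromatic ring directly on it are both compatible with the lower number, and 2,6-dichlorobenzyl is so far the only group that stands apart. Nothing available explains why this group stands apart or why the other two match.

Still open, going by these compounds, is whether the high number of compound 2 belongs to the benzyl link or to the two chlorine atoms, which an unsubstituted benzyl group would separate. Equally open, on these data alone, is how far the position tolerates change around phenethylcarbonyl, for instance a shorter or longer chain between carbonyl and phenyl ring, or a terminal amine or carboxylic acid in place of the phenyl ring.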